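Lengthening the chain on compound 2

The source may report more compounds than this note shows. Statements on the series, on what has been measured and on what is new or still open speak of the compounds shown alone.

Of the compounds shown here, three have been measured so far. In a functional assay on NCI-H460 cells (Homo sapiens) for inhibition, with a stated time of 72 h (a lower number here means a stronger inhibitor, a higher number a weaker inhibitor), compound 1 `COc1cc(C(=O)c2cccc3c2ccn3C)cc(OC)c1OC` gives 28.8 nM, compound 2 `COc1cc(C(=O)c2ccc3c(ccn3C)c2)cc(OC)c1OC` gives 14.1 nM, and compound 3 `CCn1ccc2cc(C(=O)c3cc(OC)c(OC)c(OC)c3)ccc21` gives 38 nM. Compound 2 therefore has the lowest number of the three, which makes it the strongest inhibitor among them.

Compound 4 `COc1cc(C(=O)c2ccc3c(ccn3CCN(C)C)c2)cc(OC)c1OC` has not yet been measured. Its difference from compound 2 is (dimethylamino)methyl in place of hydrogen on a saturated chain carbon bound to an aromatic nitrogen, which turns a methyl into a 2-(dimethylamino)ethyl. Among the compounds with values here, one measured step bears on this change: a 2.7-fold higher number from compound 2 to compound 3 (0.43 log units; beyond the scatter). That step is modest but beyond the scatter, and it comes from methyl in place of hydrogen at the same place. Within the data shown here, no measured compound carries the dimethylamino group, so this single step is only a rough guide. A step of similar size towards a higher number, meaning a weaker inhibitor, is expected in this assay. The estimated change is a 2.8-fold higher number from compound 2 to compound 4 (0.45 log units; beyond the scatter). For compound 4 the expected value is 40 nM, with an estimated range from 12 nM to 130 nM.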

Compound 4, half-maximal inhibitory concentration: 5100 nM
Compound 4: middle estimate off by 130-fold (2.11 log units), on the low side, outside the stated range (above it).
By their numbers in this assay, from the lowest: compound 2; then compounds 1 and 3 (each within the scatter of the next); then compound 4.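

In this assay, within the data shown here, this position proves far less forgiving than the earlier compounds suggested: (dimethylamino)methyl in place of hydrogen on a saturated chain carbon bound to an aromatic nitrogen brings a 360-fold higher number from compound 2 to compound 4 (2.56 log units; beyond the scatter) and leaves a much weaker inhibitor. Most of that loss comes with the last addition, as dimethylamino in place of hydrogen on a saturated chain carbon, two bonds along the chain from an aromatic nitrogen, brings a 130-fold higher number from compound 3 to compound 4 (2.13 log units; beyond the scatter) and dwarfs the earlier 2.7-fold higher number from compound 2 to compound 3 (0.43 log units; beyond the scatter) on going from methyl to the next chain length. Nothing shown here explains why this added group costs so much.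

The compounds shown leave open whether a plain propyl chain would stay close to compound 3 or fall towards compound 4. They also leave open how a 2-hydroxyethyl chain or a 2-(morpholin-4-yl)ethyl chain would compare with the 2-(dimethylamino)ethyl chain.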